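The compounds below may be only part of what the source reports. "The series", "measured", "known", "first", "only" and "open" are said of these compounds alone.

Among the compounds with values here, compound 2 `Cc1ccc(-c2ccc(C)n2-c2ccc(-c3nc4ccc(F)cc4s3)cc2)cc1` is one of two compounds measured in a functional assay on MCF7 cells (Homo sapiens) for cytotoxicity, read by MTT assay, with a stated time of 72 h (on this read-out higher numbers stand for weaker inhibition and lower numbers for stronger inhibition), where compound 2 gives 2970 nM. Its companion, compound 1 `Cc1ccc(-c2ccc(C)n2-c2ccc(-c3nc4ccccc4s3)cc2)cc1`, carries a hydrogen where compound 2 carries a fluorine; in this assay compound 1 gives 3100 nM, and the step of a 1.0-fold lower number from compound 1 to compound 2 (0.02 log units; within the scatter) lies within the scatter, so the two numbers show no separation. Compound 3 `COc1ccc(-c2ccc(C)n2-c2ccc(-c3nc4ccc(F)cc4s3)cc2)cc1` is not yet measured. It differs from compound 2 by methoxy in place of methyl on an aromatic carbon. Within the data shown here, no measured step touches this exchange; the only step in hand concerns fluorine for hydrogen and stayed within the scatter. With nothing pointing either way, no move beyond the scatter is expected. For compound 3 the expected step is a 1.0-fold higher number from compound 2 to compound 3 (0.00 log units; within the scatter), within the scatter. The estimate for compound 3 in this assay is 3000 nM, within a range from 1500 nM to 6000 nM.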

Compound 3, half-maximal inhibitory concentration: 2550 nM
Compound 3: middle estimate off by 1.2-fold (0.07 log units), on the high side; low and high end bracket the measured number.
By their numbers in this assay, from the lowest: compounds 3, 2 and 1 (each within the scatter of the next).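

In this assay, the exchange of 4-methylphenyl for 4-methoxyphenyl gives a 1.2-fold lower number from compound 2 to compound 3 (0.07 log units; within the scatter), so this change, on a six-membered aromatic ring of carbon only and para to a large group, brings no separation. Within the data shown here, the earlier pair spoke only to fluorine in place of hydrogen; this step is the first reading at this position, and it shows that an oxygen can enter here without the number leaving the scatter. Nothing measured on these compounds offers an account of this result.

The compounds shown leave open whether an amine, a carboxylic acid or a longer chain at this position would move the number beyond the scatter. They also leave open whether methoxy would read the same on the core of compound 1, which carries hydrogen where compound 3 carries fluorine.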